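Ring substitution on compound 1 and a methoxy analogue

The compounds below may be only part of what the source reports. "The series", "measured", "known", "first", "only" and "open" are said of these compounds alone.

For the measured compounds named here, compound 1 `COc1cccc(OC)c1OCCNCCOc1ccccc1OCc1ccccc1` gives 8.39 in a functional assay on Vas deferens for antagonist activity at Alpha-1A adrenergic receptor (Rattus norvegicus) (a higher number here means a more potent compound, by a factor of ten per unit of this negative logarithm, a lower number a less potent compound), the lower of the two measured numbers; compound 2 `COc1cccc(OC)c1OCCNCCOc1ccccc1OCc1cccc([N+](=O)[O-])c1` gives 8.85, and a number 0.46 log units higher from compound 1 to compound 2 (beyond the scatter) is the only measured step. Compound 3 `COc1ccccc1COc1ccccc1OCCNCCOc1c(OC)cccc1OC` differs from compound 1 by methoxy in place of hydrogen on an aromatic carbon. The measured step concerns a different entering group on that ring, so it bears on compound 3 only as a sign that substitution there is tolerated. For compound 3 a step of similar size or smaller is expected, a number 0.11 log units higher from compound 1 to compound 3 (within the scatter). For compound 3 the estimate in this assay is 8.5, with a range of 8 to 9.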

Compound 3, negative logarithm of the antagonist equilibrium constant: 8.53
Estimate against measurement, compound 3: 0.03 log units below; low and high end bracket the measured number.
By their numbers in this assay, from the lowest: compounds 1 and 3 (each within the scatter of the next); then compound 2.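

In this assay, 2-methoxybenzyl in place of benzyl gives a number 0.14 log units higher from compound 1 to compound 3 (within the scatter), so compound 3 and compound 1 cannot be told apart at this position. Against the nitro analogue, 2-methoxyphenyl in place of 3-nitrophenyl gives a number 0.32 log units lower from compound 2 to compound 3 (beyond the scatter), which leaves compound 2 the most potent of the three. No evidence bears on this difference.

Still open, going by these compounds, is how an amine or a carboxylic acid on this ring would read. The compounds shown also leave open whether a 3-methoxyphenyl group would match 2-methoxyphenyl or 3-nitrophenyl.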